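Replacing an Acetyl Methyl with a Nitrophenyl Ring

The source may report more compounds than this note shows. Statements on the series, on what has been measured and on what is new or still open speak of the compounds shown alone.

Compound 1, `O=C(CSc1nc2ccc(NC(=O)c3ccc(Cl)cc3)cc2s1)NCc1ccc(Cl)cc1`, gives 17800 nM in a functional assay on HepG2 cells (Homo sapiens) for cytotoxicity, read by MTT assay, with a stated time of 48 h; on this read-out higher numbers stand for weaker inhibition and lower numbers for stronger inhibition.
Compound 2, `O=C(CSc1nc2ccc(NC(=O)c3ccccc3)cc2s1)NCc1ccc(Cl)cc1`, gives 30100 nM in this assay.
Compound 3, `CC(=O)Nc1ccc2nc(SCC(=O)NCc3ccc(Cl)cc3)sc2c1`, gives 6700 nM in this assay.

Of these three, compound 3 carries the lowest number, meaning the strongest inhibition of cell growth, and both steps leading to it, a 2.7-fold lower number from compound 1 to compound 3 (0.42 log units; beyond the scatter) and a 4.5-fold lower number from compound 2 to compound 3 (0.65 log units; beyond the scatter), lie beyond the scatter, so it is the most potent of the set. Compound 1 and compound 2 differ only by a 1.7-fold higher number from compound 1 to compound 2 (0.23 log units; within the scatter), which stays within the scatter.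

The next compound, compound 4, `O=C(CSc1nc2ccc(NC(=O)c3ccc([N+](=O)[O-])cc3)cc2s1)NCc1ccc(Cl)cc1`, differs from compound 3 by 4-nitrophenyl in place of methyl on a carbonyl carbon. The two measured steps bear directly on this change, but run the other way: in each, an aromatic ring on that carbonyl carbon was replaced by methyl and the number fell modestly. Putting an aromatic ring back is therefore expected to raise the number again by a similar modest amount. For compound 4 the expected step is a 3.3-fold higher number from compound 3 to compound 4 (0.52 log units; beyond the scatter). The estimate for compound 4 in this assay is 22000 nM, within a range from 8000 nM to 60000 nM.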

Compound 4, half-maximal inhibitory concentration: > 100000 nM
Compound 4 ended at the assay's limit; the forecaster's own chance of this, stated with the estimate: 10%; at least 4.5-fold (0.65 log units) between middle value and limit.
By their numbers in this assay, from the lowest: compound 3; then compounds 1 and 2 (each within the scatter of the next). At a limit, above all of these: compound 4.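

In this assay compound 4 gives > 100000 nM as a limit of the assay and not a number: the limit of > 100000 nM in this assay, at which 1 of the 4 values shown sits.

With 4-nitrophenyl in place of methyl on the carbonyl carbon, the change is an at least 14-fold higher number from compound 3 to compound 4 (1.17 log units; beyond the scatter) and counts as large, whereas the earlier swaps between an aromatic ring and methyl were only modest. The group carried on that aromatic ring also proves to matter, which compounds 1 and 2 did not show, as their own step stayed within the scatter: nitro in place of hydrogen gives an at least 3.3-fold higher number from compound 2 to compound 4 (0.52 log units; beyond the scatter) and nitro in place of chloro gives an at least 5.6-fold higher number from compound 1 to compound 4 (0.74 log units; beyond the scatter) on this read-out.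

Going by these compounds, how an amine or a carboxylic acid on that ring would behave stays open, as does the effect of a longer chain in place of the acetyl methyl. On these data alone, the true size of the steps to compound 4 also remains open.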